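The source may report more compounds than this note shows. Statements on the series, on what has been measured and on what is new or still open speak of the compounds shown alone.

Measured compounds:
compound 1 `O=Cc1ccc(-c2cn3ccnc3c(-c3ccc4ncn(C5CCCCC5)c4c3)n2)cc1` — 4.21%
compound 2 `c1ccc2c(-c3cn4ccnc4c(-c4ccc5ncn(C6CCCCC6)c5c4)n3)cccc2c1` — 5.34%

In a functional assay on SW-620 cells (Homo sapiens) for inhibition, read by sulforhodamine B assay, with a stated time of 48 h, tested at 10 uM (on this read-out lower numbers stand for less inhibition and higher numbers for more inhibition at the one concentration tested (going by the name of the read-out)), compound 1 gives 4.21%. Within the data shown here, the only comparison compound, compound 2, gives 5.34% in this assay; the step of a number 1.1 percentage points higher from compound 1 to compound 2 (within the scatter) is within the scatter, so the two compounds stand level, and both show little inhibition at the single concentration tested.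

Compound 3 `O=Cc1ccc(-c2cn3ccnc3c(-c3ccc4ncn(Cc5ccccc5)c4c3)n2)cc1` is the next compound for this assay. It keeps the 4-formylphenyl of compound 1 and is changed elsewhere: benzyl in place of cyclohexyl on an aromatic nitrogen. Among the measured compounds shown here, no measured step touches the group on the aromatic nitrogen; the one step on record, a number 1.1 percentage points higher from compound 1 to compound 2 (within the scatter), concerns the other end of the shared core and was itself flat. For the measured compounds named here, it therefore gives no direction for the change in compound 3, only the observation that the series so far sits at low inhibition regardless of the group exchanged.

Compound 3 is accordingly expected to stay near compound 1, with a number 2.8 percentage points higher from compound 1 to compound 3 (within the scatter) not beyond the scatter. The estimate for compound 3 in this assay is 7%, with a range from -5% to 25%.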

Compound 3, a percentage reported as inhibition, at one concentration (the size of the read-out at that concentration, not a potency): 4.21%
Compound 3: middle estimate off by 2.8 percentage points, on the high side; measured number inside the range.
By their numbers in this assay, from the lowest: compounds 1, 3 and 2 (each within the scatter of the next).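

In this assay, among these compounds, the first step on record at this position, benzyl in place of cyclohexyl on an aromatic nitrogen of the five-membered aromatic ring, reads as no change at the digits printed from compound 1 to compound 3 (within the scatter) and so gives no sign that this exchange matters at this concentration. Replacing a non-aromatic six-membered carbon ring with a benzyl group, which brings an aromatic six-membered carbon ring and adds no hydrogen-bond donor or acceptor, leaves compound 3 at 4.21%, still little inhibition at the one concentration tested. No supporting measurement bears on this flat result.

Both groups shown on this nitrogen are made of carbon only, so the effect of a group carrying a heteroatom, such as a basic amine like piperidin-4-yl or a carboxylic acid at the end of a longer chain, remains open. Also open, as far as these compounds go, is whether benzyl and cyclohexyl would still read alike with naphthalen-1-yl in place of 4-formylphenyl, and whether either pair would separate at a concentration other than the single one reported here.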